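Chloro for bromo on the halogenated arm of compound 2

The source may hold more compounds than are shown below. What is called first, only, known or untested is meant among the compounds shown, and "the series" means these compounds.

Going by the values given here, compound 2 `Cc1cccc2cc(-c3ccc(Br)nn3)c(=O)oc12` gives 2640 nM in an assay on cells for inhibition of Amine oxidase [flavin-containing] B (Homo sapiens), read by fluorescence and Amplex Red, with a stated time of 15 min (on this read-out higher numbers stand for weaker inhibition and lower numbers for stronger inhibition), the second highest of the three numbers measured so far. Compound 1 `Cc1ccc2oc(=O)c(-c3ccc(Br)nn3)cc2c1` gives 2160 nM in this assay, within the scatter of compound 2. Among the compounds with values here, compound 3 `COc1cccc2cc(-c3ccc(Br)nn3)c(=O)oc12` gives 12900 nM in this assay; the step of a 4.9-fold higher number from compound 2 to compound 3 (0.69 log units; beyond the scatter) is the only measured step and concerns methoxy in place of methyl on an aromatic carbon. Compound 4 `Cc1cccc2cc(-c3ccc(Cl)nn3)c(=O)oc12` differs from compound 2 by chloro in place of bromo on an aromatic carbon. No measured step touches the halogen, so nothing among these compounds anchors the size of this change. The step from compound 2 to compound 4 is therefore expected to be small, a 1.3-fold higher number from compound 2 to compound 4 (0.12 log units; within the scatter), with no direction beyond the scatter. Compound 4 is estimated at 3500 nM in this assay, within a range of 1500 nM to 8500 nM.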

Compound 4, half-maximal inhibitory concentration: 22700 nM
Estimate against measurement, compound 4: 6.5-fold (0.81 log units) below, and the stated range ends below it.
By their numbers in this assay, from the lowest: compounds 1 and 2 (each within the scatter of the next); then compounds 3 and 4 (each within the scatter of the next).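

In this assay the halogen position on the six-membered aromatic ring with 2 nitrogen responds clearly to the identity of the halogen: an 8.6-fold higher number from compound 2 to compound 4 (0.93 log units; beyond the scatter), with bromo giving the lower number in this single pair. Going by these compounds alone, all the earlier compounds carried bromo, so this is the first reading at this position. Nothing available bears on why the number moves. On these data alone, whether the same gap appears on the core of compound 1 remains open. So does how an amine, a nitrile or iodo would read at this position.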